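The source may hold more compounds than are shown below. What is called first, only, known or untested is meant among the compounds shown, and "the series" means these compounds.

In an ADME assay on microsomes from liver (Homo sapiens) for metabolic stability, using NADPH, with a stated time of 10 min (on this read-out lower numbers stand for a less stable compound and higher numbers for a more stable compound), compound 1 `CCCCc1nc(=O)c(S(=O)(=O)c2ccc(-n3ccccc3=O)cc2)c(O)n1-c1c(OC)cccc1OC` gives 87% and compound 2 `COc1cccc(OC)c1-n1c(CCC(C)C)nc(=O)c(S(=O)(=O)c2ccc(-c3ccc(F)nc3)cc2)c1O` gives 89% on the same read-out, so these two lie within the scatter of each other. Compound 3 `CCCCc1nc(=O)c(S(=O)(=O)c2ccc(C3CC3)cc2)c(O)n1-c1c(OC)cccc1OC` differs from compound 1 in one place, on an aromatic carbon para to a large group, and a group of 3 heavy atoms (3 carbon; one three-membered non-aromatic ring of carbon only) in place of a group of 7 heavy atoms (5 carbon, 1 nitrogen, 1 oxygen; one six-membered aromatic ring with 1 hetero atom), on an aromatic carbon describes the change. Going by the values given here, no measured pair shows this replacement, so the data give no direct guide to its size or direction. The estimated step of a number 3 percentage points lower from compound 1 to compound 3 (within the scatter) is expected to stay within the scatter, with no firm direction. For compound 3 the expected value in this assay is 84% within an estimated range of 70% to 96% for now.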

Compound 3, percent of the compound remaining: 95%
Compound 3: the middle estimate sits 11 percentage points below what was measured; measured number inside the range.
By their numbers in this assay, from the lowest: compounds 1, 2 and 3 (each within the scatter of the next).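

In this assay, cyclopropyl in place of the group of 7 heavy atoms, on an aromatic carbon para to a large group, gives a number 8 percentage points higher from compound 1 to compound 3 (within the scatter). This first direct reading of the replacement shows that, on this read-out, the position accepts a smaller all-carbon ring with 0 hydrogen-bond acceptors without a step beyond the scatter. No measurement here offers an explanation for this result. Still open, as far as these compounds go, is how an amine or a carboxylic acid on this aromatic carbon would read in this assay. A single step also leaves open whether a longer chain there would stay within the scatter of compound 1.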